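This account rests on a few compounds, and the source may have more. Where it says the series, first, only, none or still open, it means among the compounds named here.

Measured in a functional assay on A2780 cells (Homo sapiens) for antiproliferative activity, read by fluorescence, with a stated time of 72 h; a lower number here means a stronger inhibitor, a higher number a weaker inhibitor:
compound 1 `CN1CCC(C(=O)N2Cc3c(NC(=O)NCc4ccccc4)n[nH]c3C2(C)C)CC1`: 2680 nM
compound 2 `CN1CCC(C(=O)N2Cc3c(NC(=O)Nc4cccc(F)c4)n[nH]c3C2(C)C)CC1`: 350 nM

Of these two, compound 2, at 350 nM, has the lower number in this assay. Among the compounds with values here, the only measured step is a 7.7-fold lower number from compound 1 to compound 2 (0.88 log units; beyond the scatter), which lies beyond the scatter and comes from 3-fluorophenyl in place of benzyl on an amide-type nitrogen. Compound 3 `CN1CCC(C(=O)N2Cc3c(NC(=O)c4ccc(C(F)(F)F)cc4)n[nH]c3C2(C)C)CC1` keeps the shared core and alters the group on a carbonyl carbon: 4-(trifluoromethyl)phenyl in place of (3-fluorophenyl)amino on a carbonyl carbon. Within the data shown here, no measured compound has 4-(trifluoromethyl)phenyl on that carbonyl carbon, and both measured compounds keep the amide-type nitrogen that is lost here, so the evidence is only indirect. Taking the measured step, a 7.7-fold lower number from compound 1 to compound 2 (0.88 log units; beyond the scatter), as a gauge of how far a change in this group can move the number, a step of similar or smaller size is expected in this assay. A somewhat higher number is thought slightly more likely than a lower one, though the data do not settle the direction. The expected change is a 1.4-fold higher number from compound 2 to compound 3 (0.15 log units; within the scatter). For compound 3 the estimated value is 500 nM, with an expected range from 120 nM to 2000 nM.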

Compound 3, half-maximal inhibitory concentration in the A2780 assay: 60 nM
For compound 3 the middle estimate is 8.3-fold (0.92 log units) above the measured one; measured number outside the range, below it.
By their numbers in the A2780 assay, from the lowest: compound 3; then compound 2; then compound 1.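

In the A2780 assay, the amide-type nitrogen that compound 1 and compound 2 both keep on the carbonyl carbon is not needed for a low number among these compounds: 4-(trifluoromethyl)phenyl in place of (3-fluorophenyl)amino gives a 5.8-fold lower number from compound 2 to compound 3 (0.77 log units; beyond the scatter), and in place of benzylamino it gives a 45-fold lower number from compound 1 to compound 3 (1.65 log units; beyond the scatter). In a physicochemical assay for solubility, at pH 7 (a higher number here means a more soluble compound, a lower number a less soluble compound), compound 2 gives > 225000 nM, which is a limit of the assay. In the physicochemical assay compound 3 gives 191000 nM, and the change can be read only as a floor, an at least 1.1-fold lower number from compound 2 to compound 3 (0.07 log units; that floor lies within the scatter), so it shows no clear loss of solubility. That reading is bounded by a limit of the assay for compound 2: the limit of > 225000 nM in the physicochemical assay, at which 1 of the 2 values shown sits.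

The compounds shown leave open how much of the gain in the A2780 assay belongs to the loss of the amide-type nitrogen and how much to the trifluoromethyl group, as the two changes arrive together. A 3-fluorophenyl group directly on the carbonyl carbon, or a 4-(trifluoromethyl)phenylamino group there, would pull these apart, while a nitrile or a methoxy group in place of trifluoromethyl would show whether that group itself matters.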